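Swapping a phenyl for a 4-fluorobenzyl on the piperidine

The source may report more compounds than this note shows. Statements on the series, on what has been measured and on what is new or still open speak of the compounds shown alone.

The measured compounds, each with its own number:
- compound 1 `Cc1cc(C)c(S(=O)(=O)N2CCC(N3CCC(c4ccccc4)CC3)CC2)c(C)c1` gives 865 nM in a functional assay on DLD-1 cells (Homo sapiens) for antiproliferative activity, read by CellTiter-Glo, with a stated time of 72 h; a lower number here means a stronger inhibitor, a higher number a weaker inhibitor
- compound 2 `Cc1ccc(-c2ccccc2S(=O)(=O)N2CCC(N3CCC(C)CC3)CC2)cc1` gives 366 nM in this assay
- compound 3 `CC1CCN(C2CCN(S(=O)(=O)c3cccc(Cl)c3)CC2)CC1` reaches only a limit, > 5000 nM, in this assay

Among the two values that are numbers, compound 1 stands highest: compound 2 sits at a number that is lower by an amount beyond the usual scatter of this measurement. Among the compounds with values here, the value of compound 3 is a limit of the assay and not a number; it is the one value that sits at the limit of > 5000 nM in this assay, at which 1 of the 3 values shown sits.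

Compound 4 `Cc1cc(C)c(S(=O)(=O)N2CCC(N3CCC(Cc4ccc(F)cc4)CC3)CC2)c(C)c1` differs from compound 1 in one place: 4-fluorobenzyl in place of phenyl on a saturated ring carbon. Within the data shown here, no pair of measured compounds shares exactly this change, so there is no measured step to lean on. Among the measured compounds shown here, compounds 2 and 3 show only that the groups on the far piperidine and on the sulfonyl aryl vary together, which says nothing direct about this single change.

The step from compound 1 to compound 4 is therefore expected to be small, a 1.3-fold lower number from compound 1 to compound 4 (0.12 log units; within the scatter), either within the scatter or a modest move toward a lower number. For compound 4 the estimate is 650 nM, with a range from 220 nM to 1900 nM.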

Compound 4, half-maximal inhibitory concentration: 18 nM
Beside the measured number, compound 4's estimate is 36-fold (1.56 log units) above it; measured number outside the range, below it.
By their numbers in this assay, from the lowest: compound 4; then compound 2; then compound 1. At a limit, above all of these: compound 3.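

In this assay, this saturated ring carbon, three ring bonds from the ring nitrogen, turns out to be a place where the group carried matters greatly: 4-fluorobenzyl in place of phenyl gives a 48-fold lower number from compound 1 to compound 4 (1.68 log units; beyond the scatter) with the rest of the core of compound 1 unchanged. This is the only pair shown that differs in one place, so it alone ties a change in the number to this position, which the earlier compounds, differing in several places at once, could not do. Nothing measured here accounts for the size of this step, which stands as an observation without a stated cause.

The entering group differs from phenyl in two ways at once, by its carbon link to the ring and by its fluorine, and a plain benzyl or a 4-fluorophenyl at this carbon would be needed to tell these two apart. Also open, as far as these compounds go, are how a longer chain such as 2-phenylethyl would fare here, and whether the same step holds with other aryl groups on the sulfonyl.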